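The source may report more compounds than this note shows. Statements on the series, on what has been measured and on what is new or still open speak of the compounds shown alone.

Values measured in a functional assay on KB cells (Homo sapiens) for inhibition, read by sulforhodamine B assay (on this read-out lower numbers stand for stronger inhibition of growth and higher numbers for weaker inhibition of growth), are as follows
compound 1 `Cc1ccc2[nH]c(-c3ccc(-c4ccc(-c5cccc(Cl)c5)cc4)cc3)nc2c1` gives 2260 nM
compound 2 `FC(F)(F)c1ccc(-c2ccc(-c3ccc(-c4nc5ccccc5[nH]4)cc3)cc2)cc1` gives 47200 nM

Of these two, compound 2 carries the higher number, which makes it the weaker growth inhibitor, and its gap to compound 1 lies beyond the scatter. The next compound, compound 3 (`CN(C)c1ccc(-c2ccc(-c3ccc(-c4nc5ccccc5[nH]4)cc3)cc2)cc1`), has dimethylamino in place of trifluoromethyl on an aromatic carbon, para to a large group (dimethylamino in place of trifluoromethyl on an aromatic carbon). Within the data shown here, no measured pair shows this change directly, so any expectation here is only loosely supported. Compound 2 sits at 47200 nM while compound 1 reaches 2260 nM and so in this assay a moderate step towards a lower number is expected. The estimated change is this (a 5.2-fold lower number from compound 2 to compound 3 (0.72 log units; beyond the scatter)). For compound 3 the estimated value is 9000 nM within an expected range (1800 nM to 45000 nM).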

Compound 3, concentration for 50% growth inhibition: 39300 nM
Compound 3: middle estimate off by 4.4-fold (0.64 log units), on the low side; measured number inside the range.
By their numbers in this assay, from the lowest: compound 1; then compounds 3 and 2 (each within the scatter of the next).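

In this assay, putting dimethylamino in place of trifluoromethyl on this aromatic carbon, para to a large group, gives a 1.2-fold lower number from compound 2 to compound 3 (0.08 log units; within the scatter), so the two compounds cannot be told apart. This is the first pair shown that differs in one place only, and it indicates that this particular exchange of groups, with their different atoms, leaves the growth-inhibition read-out unchanged within the usual scatter. No measurement available here accounts for this lack of a clear difference.

Going by these compounds, whether another group at this position, such as a carboxylic acid or a longer chain, would shift the number remains open. On these data alone, it is also open whether the same exchange would give a similar step on the core of compound 1.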